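This account rests on a few compounds, and the source may have more. Where it says the series, first, only, none or still open, it means among the compounds named here.

Series notes on the benzyl variation. In a toxicity assay on HEK-293T cells (Homo sapiens) for cytotoxicity, read by CCK-8 assay, with a stated time of 48 h (a lower number here means that less compound is tolerated, a higher number that more compound is tolerated), compound 1 `Cn1cc(SCc2nnc(SCc3ccccc3Cl)n2-c2c(Cl)cccc2Cl)c2ccccc21` gives 49600 nM. Compound 3 `Cn1cc(SCc2nnc(SCc3cc(C(F)(F)F)ccc3Cl)n2-c2c(Cl)cccc2Cl)c2ccccc21` gives 53800 nM in this assay. Compound 2 `Cn1cc(SCc2nnc(SCc3ccccc3OC(F)(F)F)n2-c2c(Cl)cccc2Cl)c2ccccc21` returns only a limit in this assay, > 100000 nM. Compound 2 therefore stands at the limit of > 100000 nM in this assay, at which 1 of the 3 values shown sits, and its exact position is not known.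

Compound 4 `Cn1cc(SCc2nnc(SCc3ccc(Cl)cc3Cl)n2-c2c(Cl)cccc2Cl)c2ccccc21` is not yet measured. Its change from compound 2 is 2,4-dichlorophenyl in place of 2-(trifluoromethoxy)phenyl on a saturated chain carbon bound to a sulfur. Among the compounds with values here, two measured steps bear on it. The first, an at least 2.0-fold higher number from compound 1 to compound 2 (0.30 log units; that floor lies within the scatter), took the chloro-bearing compound 1 to the limit. The second, an at least 1.8-fold lower number from compound 2 to compound 3 (0.26 log units; that floor lies within the scatter), brought the number back into the measured range. The added chloro of compound 4 has a counterpart in a 1.1-fold higher number from compound 1 to compound 3 (0.04 log units; within the scatter), where an added group on the same ring left the number unchanged. For compound 4 the expected step is an at least 1.8-fold lower number from compound 2 to compound 4 (0.25 log units; that floor lies within the scatter), downward, back toward compound 1 and compound 3, although the floors of both measured steps lie within the scatter, so a change beyond it is expected only weakly. The estimated value for compound 4 is 55000 nM, with a range from 25000 nM to 120000 nM.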

Compound 4, half-maximal cytotoxic concentration: > 100000 nM
Compound 4: only a limit was reported (the forecaster's own chance of this, stated with the estimate: 30%); middle value at least 1.8-fold (0.25 log units) away from the limit.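

In this assay compound 4 returns only a limit and not a number, so a ring without the trifluoromethoxy group also reaches this end of the range at the saturated chain carbon bound to a sulfur: the limit of > 100000 nM in this assay, at which 2 of the 4 values shown sit. Chloro in place of hydrogen on an aromatic carbon gives an at least 2.0-fold higher number from compound 1 to compound 4 (0.30 log units; that floor lies within the scatter), and 2,4-dichlorophenyl in place of 2-chloro-5-(trifluoromethyl)phenyl gives an at least 1.8-fold higher number from compound 3 to compound 4 (0.26 log units; that floor lies within the scatter). Taken together, these steps show that a second chloro on the benzyl ring can leave the number at a limit, although each printed floor is too small to establish a real difference. The ring of compound 3, which carries a trifluoromethyl group, still gives a measured 53800 nM.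

From the compounds shown here alone, the step between compound 2 and compound 4 cannot be read, since both values are limits, and their true order in this assay remains open. Also open, going by these compounds, is where a benzyl ring bearing an amine, a carboxylic acid or a methoxy group would stand, and whether a compound with a second chloro elsewhere on the ring would also reach the limit.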